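Fluorine on the Benzyl Ring of a Pyrazole Amide

A few compounds are considered here, and "the series" means these few. Any claim that something is new, unique, unknown or untested is made for them only; others in the source may bear on it.

Measured compounds:
compound 1 `O=C(NOCc1ccccc1F)c1cn(-c2ccccc2)nc1-c1ccccc1` gives 16100 nM in a functional assay on MCF7 cells (Homo sapiens) for antiproliferative activity, read by MTT assay, with a stated time of 48 h, in the presence of a further agent that is not named here; on this read-out higher numbers stand for weaker inhibition of growth and lower numbers for stronger inhibition of growth;
compound 2 `Cc1ccc(-c2nn(-c3ccccc3)cc2C(=O)NOCc2ccccc2)cc1` gives 1870 nM in this assay.

Compound 2 stands lowest of the two numbers; its nearest neighbour is compound 1, whose number is higher by a gap beyond the scatter. Compound 3 `Cc1ccc(-c2nn(-c3ccccc3)cc2C(=O)NOCc2ccccc2F)cc1` differs from compound 2 by fluoro in place of hydrogen on an aromatic carbon. For the measured compounds named here, no measured pair shows this single change alone, so the data give no direct guide to its size or direction. Compound 3 is therefore expected to stay close to compound 2, with the step of a 1.6-fold higher number from compound 2 to compound 3 (0.21 log units; within the scatter) estimated at no more than a modest rise. The expected value for compound 3 in this assay is 3000 nM, within 800 nM to 12000 nM.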

Compound 3, concentration for 50% growth inhibition: 2110 nM
Beside the measured number, compound 3's estimate is 1.4-fold (0.15 log units) above it; the range from low to high includes it.
By their numbers in this assay, from the lowest: compounds 2 and 3 (each within the scatter of the next); then compound 1.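

In this assay, the change from benzyl to 2-fluorobenzyl gives a 1.1-fold higher number from compound 2 to compound 3 (0.05 log units; within the scatter), so fluoro at this place, ortho to a large group, makes no difference that can be told from the scatter. With the 2-fluorobenzyl kept, the added methyl gives a 7.6-fold lower number from compound 1 to compound 3 (0.88 log units; beyond the scatter), a step beyond the scatter. No measurement here offers a reason for either step. Going by these compounds, whether a chloro, a methoxy or an amine at this same place would also stay within the scatter remains open.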